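Cyano for Amino on a Diaryl Ether Benzamide

The source may report more compounds than this note shows. Statements on the series, on what has been measured and on what is new or still open speak of the compounds shown alone.

Measured so far:
compound 1 `COc1ccc(NC(=O)c2cc(N)ccc2Oc2ccc(OC)cc2)cc1` — "no significant activity" (no number reported)
compound 2 `COc1ccc(Oc2ccc([N+](=O)[O-])cc2C(=O)Nc2ccc(Cl)cc2)cc1` — 10100 nM

In a functional assay (Homo sapiens) for inhibition, using a membrane potential dye, in the presence of a further agent that is not named here (on this read-out lower numbers stand for stronger inhibition and higher numbers for weaker inhibition), compound 1 gives "no significant activity" (no number reported), so it carries no number to stand on; compound 2 in this assay gives 10100 nM, a weak result. Compound 3 `COc1ccc(NC(=O)c2cc(C#N)ccc2Oc2ccc(OC)cc2)cc1` differs from compound 1 by cyano in place of amino on an aromatic carbon. Among the compounds with values here, with no measured step of this kind, only a modest shift is expected in this assay, and its direction is open; whatever compound 3 shows will likely stay in the weak region where compound 2 lies. Compound 3 is estimated at 10000 nM in this assay, with a range from 3000 nM to 30000 nM.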

Compound 3, half-maximal inhibitory concentration: 2500 nM
Compound 3: the middle estimate sits 4.0-fold (0.60 log units) above what was measured, and the stated range ends above it.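

In this assay, within the data shown here, compound 1 gives "no significant activity" (no number reported) and compound 3 gives 2500 nM, so no step between them can be read. The compounds shown leave open how far cyano in place of amino shifts inhibition, and no measurement shown explains the result.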